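The source may report more compounds than this note shows. Statements on the series, on what has been measured and on what is new or still open speak of the compounds shown alone.

In a functional assay on PANC-1 cells (Homo sapiens) for inhibition, read by MTT assay, with a stated time of 24 h, tested at 10 uM (a higher number here means more inhibition at the concentration tested (going by the name of the read-out), a lower number less inhibition), the measured compounds gave:

Compound 1 `CC(C)=CCC/C(C)=C/CC1Cc2c(OCCCNS(=O)(=O)c3ccc(Cl)cc3)cc(=O)n(CCCO)c2CC1(C)C`: 14.5%
Compound 2 `CC(C)=CCC/C(C)=C/CC1Cc2c(OCCCNC(=O)c3cccs3)cc(=O)n(CCCO)c2CC1(C)C`: 72.8%
Compound 3 `CC(C)=CCC/C(C)=C/CC1Cc2c(OCCCNC(=O)c3ccc([N+](=O)[O-])cc3)cc(=O)n(CCCO)c2CC1(C)C`: 16.8%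

Compound 3 stands second highest of the three, though a number 2.3 percentage points higher from compound 1 to compound 3 (within the scatter) keeps it level with compound 1, while a number 56 percentage points lower from compound 2 to compound 3 (beyond the scatter) places it far under compound 2. Compound 4 `COc1ccc(OCCCOc2cc(=O)n(CCCO)c3c2CC(C/C=C(\C)CCC=C(C)C)C(C)(C)C3)cc1` differs from it by 4-methoxyphenoxy in place of ((4-nitrophenyl)carbonyl)amino on a saturated chain carbon, three bonds along the chain from an oxygen on an aromatic ring. Within the data shown here, every measured step so far swaps one group on that amine nitrogen; none replaces the whole nitrogen-linked group by an ether, so no direct guide exists. The large swing in a number 56 percentage points lower from compound 2 to compound 3 (beyond the scatter) shows that this chain end can move the read-out strongly in either direction. Compound 4 is therefore estimated at 30%, with a wide range from 8% to 65%, which is an expected step of a number 13.2 percentage points higher from compound 3 to compound 4 (beyond the scatter).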

Compound 4, a percentage reported as inhibition, at one concentration (the size of the read-out at that concentration, not a potency): 20%
Compound 4: middle estimate off by 10 percentage points, on the high side; the range from low to high includes it.
By their numbers in this assay, from the lowest: compounds 1, 3 and 4 (each within the scatter of the next); then compound 2.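

In this assay, the 4-methoxyphenoxy end carries no nitrogen, yet it reads level with two nitrogen-linked ends: a number 3.2 percentage points higher from compound 3 to compound 4 (within the scatter) and a number 5.5 percentage points higher from compound 1 to compound 4 (within the scatter). The ((thiophen-2-yl)carbonyl)amino end alone stands apart, with a number 52.8 percentage points lower from compound 2 to compound 4 (beyond the scatter), so replacing the nitrogen-linked group with this ether gives no gain over compounds 1 and 3. Still open, as far as these compounds go, is whether the high number of compound 2 depends on the thiophen-2-yl group or on its amide link. A free amine or a carboxylic acid at the chain end, or a longer chain, could also be informative. Nothing available gives a cause for these numbers.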